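From Isobutyl to Cyclohexyl on Compound 3

A few compounds are considered here, and "the series" means these few. Any claim that something is new, unique, unknown or untested is made for them only; others in the source may bear on it.

In a functional assay on HL-60 cells (Homo sapiens) for cytotoxicity, read by MTT assay, with a stated time of 72 h (on this read-out lower numbers stand for stronger inhibition and higher numbers for weaker inhibition), compound 1 (`CC(C)(C)c1nc2ccccc2n1C(=O)c1cccc2ccccc12`) gives 130 nM and compound 2 (`O=C(c1cccc2ccccc12)n1c(C2CCC2)nc2ccccc21`) gives 180 nM as its reading. Compound 3 (`COc1ccc(C(=O)n2c(CC(C)C)nc3ccccc32)cc1`) reads 34 nM and so holds the lowest of the three numbers, beyond the scatter from both of the others. Compound 4 (`COc1ccc(C(=O)n2c(C3CCCCC3)nc3ccccc32)cc1`) has not yet been measured. It differs from compound 3 by cyclohexyl in place of isobutyl on an aromatic carbon between two ring nitrogen atoms.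

Among the compounds with values here, only one measured step bears on this change. It puts cyclobutyl in place of tert-butyl at that same place and amounts to a 1.4-fold higher number from compound 1 to compound 2 (0.14 log units; within the scatter) on the scale of this assay and so lies within the scatter. Within the data shown here, it is a loose guide, since compound 1 and compound 2 carry a different group on the carbonyl from compound 3, and no measured step starts from isobutyl. A small change is therefore expected, with a slight lean upward since compound 3 at 34 nM already sits lowest. The estimated step is a 1.5-fold higher number from compound 3 to compound 4 (0.17 log units; within the scatter) and may well not exceed the scatter. Compound 4 is expected at 50 nM with an estimated range from 16 nM to 150 nM as its likely span.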

Compound 4, half-maximal inhibitory concentration: 85 nM
Estimate against measurement, compound 4: 1.7-fold (0.23 log units) below; the measured number falls inside the stated range.
By their numbers in this assay, from the lowest: compound 3; then compounds 4, 1 and 2 (each within the scatter of the next, the first and the last beyond it).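

In this assay, the exchange of isobutyl for cyclohexyl amounts to a 2.5-fold higher number from compound 3 to compound 4 (0.40 log units; beyond the scatter), so the group on this aromatic carbon between two ring nitrogen atoms can move the reading beyond the scatter. Within the data shown here, the only earlier step at this place, a 1.4-fold higher number from compound 1 to compound 2 (0.14 log units; within the scatter), had stayed within the scatter and showed no such sensitivity, though that step and the new one differ in both the groups exchanged and the group on the carbonyl. Nothing available here accounts for the size or direction of the new step.

This single exchange adds a six-membered non-aromatic ring of carbon only and also raises the heavy-atom count from 4 to 6, so the compounds shown cannot separate the effect of the ring from that of the added carbon atoms. They also leave open how a straight butyl chain, a phenyl ring or a chain ending in an amine would read at this place, and whether cyclohexyl in place of isobutyl would give a similar step with the carbonyl group of compound 1.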